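Sulfonamide series: tetrazole for carboxylate at the piperidine sulfonyl

The compounds below may be only part of what the source reports. "The series", "measured", "known", "first", "only" and "open" are said of these compounds alone.

Measured so far:
compound 1 `O=C(O)c1cccc(S(=O)(=O)N2CCC(NS(=O)(=O)c3cc(S(=O)(=O)c4ccccc4)ccc3C(F)(F)F)CC2)c1` — 20 nM
compound 2 `O=C(O)c1ccc(S(=O)(=O)N2CCC(NS(=O)(=O)c3cc(S(=O)(=O)c4ccccc4)ccc3C(F)(F)F)CC2)cc1` — 20 nM

In an assay on isolated protein for displacement of a labelled ligand from secreted frizzled-related protein 1 (Homo sapiens), read by fluorescence polarization, with a stated time of 30 min (a lower number here means a stronger inhibitor, a higher number a weaker inhibitor), compound 2 gives 20 nM and stands level with compound 1 within the scatter; the step of no change at the digits printed from compound 1 to compound 2 (within the scatter) shows that moving the carboxy group around the ring changed nothing beyond the scatter. Compound 3 `O=S(=O)(NC1CCN(S(=O)(=O)c2cccc(-c3nnn[nH]3)c2)CC1)c1cc(S(=O)(=O)c2ccccc2)ccc1C(F)(F)F` differs from compound 2 by 3-(1H-tetrazol-5-yl)phenyl in place of 4-carboxyphenyl on a sulfonyl sulfur. Within the data shown here, no measured step covers exchanging the carboxy group for a tetrazole, so the only measured step bears on it indirectly, and a step of a 1.3-fold higher number from compound 2 to compound 3 (0.10 log units; within the scatter) is expected, none beyond the scatter. For compound 3 in this assay the estimate is 25 nM, with a range from 8 nM to 80 nM.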

Compound 3, half-maximal inhibitory concentration: 30 nM
For compound 3 the middle estimate is 1.2-fold (0.08 log units) below the measured one; low and high end bracket the measured number.
By their numbers in this assay, from the lowest: compounds 1, 2 and 3 (each within the scatter of the next).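

In this assay the exchange of carboxy for 1H-tetrazol-5-yl on an aromatic carbon stays within the scatter (a 1.5-fold higher number from compound 1 to compound 3 (0.18 log units; within the scatter)), so at this place on the sulfonyl sulfur the series accepts either group. With the attachment point on the ring changed as well, the result is also within the scatter (a 1.5-fold higher number from compound 2 to compound 3 (0.18 log units; within the scatter)). No measurement at hand explains this result.

On these data alone, whether either group is needed at all remains open. An unsubstituted phenyl, a primary amide or an amine on this ring could give a different number.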